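The source may report more compounds than this note shows. Statements on the series, on what has been measured and on what is new or still open speak of the compounds shown alone.

Measured so far:
Compound 1, `Cc1ccccc1-c1nnc(N(N)c2ccccc2)s1`: in a functional assay on the whole organism with Mus musculus as the target, with a stated time of 1 h (on this read-out lower numbers stand for an effect already at smaller amounts and higher numbers for an effect only at larger amounts of compound), compound 1 gives > 100 mg/kg, a limit of the assay.
Compound 2, `Cc1ccccc1-c1nnc(N(N)Cc2ccccc2)s1`: in this assay compound 2 gives 44 mg/kg.
Compound 3, `NN(c1ccccc1)c1nnc(-c2ccccc2Cl)s1`: in this assay compound 3 gives > 100 mg/kg, again a limit of the assay.

Compound 3 differs from compound 1 by chloro in place of methyl on an aromatic carbon. The step that the two limits leave unreadable from compound 1 to compound 3 cannot be read because the limit of > 100 mg/kg in this assay, at which 2 of the 3 values shown sit, holds both values. Compound 2 differs from compound 1 by benzyl in place of phenyl on a nitrogen on an aromatic ring, and this gives an at least 2.2-fold lower number from compound 1 to compound 2 (0.35 log units; beyond the scatter).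

Compound 4, `NN(Cc1ccccc1)c1nnc(-c2ccccc2Cl)s1`, is not yet measured. It carries the same change relative to compound 3, namely (benzyl in place of phenyl on a nitrogen on an aromatic ring); the place is described in the same words, so this is the same change. For compound 4 a step of an at least 1.6-fold lower number from compound 3 to compound 4 (0.22 log units; that floor lies within the scatter) in this assay is expected, resting on the step of an at least 2.2-fold lower number from compound 1 to compound 2 (0.35 log units; beyond the scatter) seen with compound 2. Compound 4 is therefore estimated at 60 mg/kg, expected between 25 mg/kg and 150 mg/kg.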

Compound 4, dose for half-maximal effect: 143 mg/kg
Estimate against measurement, compound 4: 2.4-fold (0.38 log units) below; low and high end bracket the measured number.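

In this assay compound 3 gives > 100 mg/kg, which is a limit of the assay. The steps from compound 1 to compound 3 and from compound 3 to compound 4 cannot be read, so carrying benzyl in place of phenyl over to the chloro core is neither confirmed nor refuted, and both steps rest on this limit: the limit of > 100 mg/kg in this assay, at which 2 of the 4 values shown sit. What can be read is a 3.3-fold higher number from compound 2 to compound 4 (0.51 log units; beyond the scatter), for chloro in place of methyl with benzyl held fixed, while the benzyl change itself has a readable size on one core only, as an at least 2.2-fold lower number from compound 1 to compound 2 (0.35 log units; beyond the scatter).

The compounds shown leave open how a longer chain such as phenethyl would read in place of benzyl on that nitrogen. They also leave open how a carboxylic acid or an amine on the benzyl ring would read in this assay.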